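The source may hold more compounds than are shown below. What is called first, only, known or untested is meant among the compounds shown, and "the series" means these compounds.

In a functional assay on K562 cells (Homo sapiens) for inhibition, read by trypan blue exclusion, with a stated time of 24 h, tested at 10 uM (a higher number here means more inhibition of growth at the concentration tested, a lower number less inhibition of growth), compound 1 (`Cc1ccc(OCC(=O)Nc2ccccc2C(N)=O)cc1`) gives < 10%, and this is a limit of the assay, not a number. For the measured compounds named here, compound 2 (`Cc1ccccc1OCC(=O)Nc1ccc(Cl)cc1C(N)=O`) gives 75.9%, the only true number so far. The next compound to read is compound 3 (`Cc1ccc(OCC(=O)Nc2ccc(Cl)cc2C(N)=O)cc1`), which has the same atoms as compound 2, joined differently: 4-methylphenyl in place of 2-methylphenyl on an oxygen on a saturated carbon. Going by the values given here, no measured pair shows what a move of this kind does, so the expectation is anchored only on compound 2 at 75.9%. A moderate fall in growth inhibition is expected, with wide uncertainty, and a result within the usual scatter would not be a surprise. The expected change is a number 17.9 percentage points lower from compound 2 to compound 3 (beyond the scatter). For compound 3 the estimate is 58%, with an expected range of 25% to 85%.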

Compound 3, percent growth inhibition at one concentration: 24.1%
For compound 3 the middle estimate is 33.9 percentage points above the measured one; measured number below the stated range.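

In this assay, 4-methylphenyl in place of 2-methylphenyl on an oxygen on a saturated carbon, with the same atoms joined differently, gives a number 51.8 percentage points lower from compound 2 to compound 3 (beyond the scatter), so at this place the arrangement of the atoms alone separates the two compounds. With 4-methylphenyl held in place, chloro in place of hydrogen on an aromatic carbon gives a number at least 14.1 percentage points higher from compound 1 to compound 3 (beyond the scatter), so the chloro also counts in this series, though the size of that step stays bounded on one side only. The value of compound 1 is a limit of the assay, not a number: the limit of < 10% in this assay, at which 1 of the 3 values shown sits.

Open, going by these compounds, is what the chloro does with 2-methylphenyl in place. Also open, on these data alone, is whether other groups on that oxygen, such as unsubstituted phenyl or 2-methoxyphenyl, or a carboxylic acid or nitrile in place of the amide, keep growth inhibition.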